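Swapping Fluoro for Ethoxy on a Thiadiazole Amide

A few compounds are considered here, and "the series" means these few. Any claim that something is new, unique, unknown or untested is made for them only; others in the source may bear on it.

Compound 1, `COc1cccc(OC)c1C(=O)Nc1nnc(-c2ccc(Cl)cc2)s1`: 58.9 nM
Compound 2, `O=C(Nc1nnc(-c2ccc(Cl)cc2)s1)c1ccccc1F`: 724 nM

Of the compounds shown here, two built on the same core have been measured in a functional assay on the whole organism (integument) for inhibition, with Chilo suppressalis as the target, read by scintillation counting, with a stated time of 72 h; a lower number here means a stronger inhibitor, a higher number a weaker inhibitor. Compound 1 carries two methoxy groups on its amide-bearing ring, and in this assay compound 1 gives 58.9 nM. Compound 2 carries a single fluoro group instead, and in this assay compound 2 gives 724 nM. Compound 2 therefore stands as the weaker of the two, with a gap to compound 1 that lies beyond the usual scatter.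

Compound 3, `CCOc1ccccc1C(=O)Nc1nnc(-c2ccc(Cl)cc2)s1`, has not yet been measured. Its change from compound 2 is ethoxy in place of fluoro on an aromatic carbon. For the measured compounds named here, since no measured pair differs by this change alone, the size of the step can only be expected, not read off. Going by the values given here, because compound 1, the only alkoxy-bearing compound here, gives 58.9 nM, an improvement is expected for compound 3, though a smaller one than the whole gap to compound 1. The expected step is a 4.0-fold lower number from compound 2 to compound 3 (0.60 log units; beyond the scatter), toward a lower number. Compound 3 is estimated at 180 nM, within a range of 60 nM to 550 nM.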

Compound 3, half-maximal inhibitory concentration: > 5010 nM
Compound 3: no number, only a limit; the forecaster's own chance of this, stated with the estimate: 2%; middle value at least 27-fold (1.44 log units) away from the limit.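

In this assay compound 3 gives > 5010 nM as a limit of the assay and not as a number. Ethoxy in place of fluoro on an aromatic carbon, ortho to a large group, still yields a readable step of an at least 6.9-fold higher number from compound 2 to compound 3 (0.84 log units; beyond the scatter) and this is the first single change at this place that the data can show, running toward a weaker inhibitor. This place on the ring is therefore sensitive to what it carries, with fluoro and its single heavy atom clearly better than ethoxy and its three, and the one further fact available about the reading is where it sits: the limit of > 5010 nM in this assay, at which 1 of the 3 values shown sits.

The compounds shown leave open how a chloro group, an amine or a longer chain such as butoxy would read at this same place, and so whether the loss follows from the size of the group or from something else. As far as these compounds go, the true size of the step stays open as well, and with it how much strength this place can lose.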